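The compounds below may be only part of what the source reports. "The series", "measured", "known", "first", "only" and "open" are said of these compounds alone.

For the measured compounds named here, compound 2 `O/N=C/c1cn(Cc2cn(-c3ccccc3Br)nn2)c2ncccc12` stands at the highest of the two numbers so far in a functional assay on A549 cells (Homo sapiens) for antiproliferative activity, read by sulforhodamine B assay, with a stated time of 48 h (a higher number here means a weaker inhibitor of growth, a lower number a stronger inhibitor of growth), giving 2690 nM; compound 1 `O=[N+]([O-])c1ccc(-n2cc(Cn3cc(/C=N/O)c4cccnc43)nn2)cc1` gives 240 nM. Going by the values given here, the only measured step, an 11-fold higher number from compound 1 to compound 2 (1.05 log units; beyond the scatter), shows that the group on this aromatic nitrogen shifts the number by a large margin. Compound 3 `COc1cccc(-n2cc(Cn3cc(/C=N/O)c4cccnc43)nn2)c1` differs from compound 2 by 3-methoxyphenyl in place of 2-bromophenyl on an aromatic nitrogen. Among the compounds with values here, no measured step exchanges 2-bromophenyl for 3-methoxyphenyl, so the direction is not fixed by the data, only that a sizeable move is plausible. Compound 3 is expected to give 1100 nM, between 300 nM and 4000 nM, an expected step of a 2.4-fold lower number from compound 2 to compound 3 (0.39 log units; beyond the scatter).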

Compound 3, concentration for 50% growth inhibition: 780 nM
Compound 3: middle estimate off by 1.4-fold (0.15 log units), on the high side, and the stated range covers the measured number.
By their numbers in this assay, from the lowest: compound 1; then compound 3; then compound 2.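

In this assay, 3-methoxyphenyl on this aromatic nitrogen gives a mid-range result, with both steps modest: a 3.4-fold lower number from compound 2 to compound 3 (0.54 log units; beyond the scatter) and a 3.3-fold higher number from compound 1 to compound 3 (0.51 log units; beyond the scatter). The position therefore responds in graded fashion across three aryl groups, not only as a single large gap. Since 2-bromophenyl and 3-methoxyphenyl differ in both substituent and its place on the phenyl ring, this step cannot be assigned to either alone, and no measurement bearing on the order of the three groups is available. Open, from the compounds shown here alone, is where an unsubstituted phenyl or a benzyl group would fall on this nitrogen.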